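The compounds below may be only part of what the source reports. "The series", "measured", "known", "first", "only" and "open" are said of these compounds alone.

Measured so far:
compound 1 `CNC(=O)CC1CCc2cc(OC)c(OC)cc21`: 30%
compound 2 `COc1cc2c(cc1OC)C(CC(=O)NC(C)C)CC2`: 37%

In a functional assay on the whole organism (strain Wistar) for inhibition, with Rattus norvegicus as the target, read by paw edema, with stated times of 60 min and 2 h, at a dose of 100 mg/kg by the oral route (a higher number here means more inhibition at the dose given (going by the name of the read-out), a lower number less inhibition), compound 2 and compound 1 lie within the scatter of each other, the step being a number 7 percentage points higher from compound 1 to compound 2 (within the scatter), so on these two numbers the inhibition of compound 2 in this assay cannot be called the higher. Compound 3 `CCCCCNC(=O)CC1CCc2cc(OC)c(OC)cc21` has not been measured. It differs from compound 2 as follows: pentyl in place of isopropyl on an amide-type nitrogen. Among the measured compounds shown here, the only measured step that bears on this is the earlier change on the same amide-type nitrogen, a number 7 percentage points higher from compound 1 to compound 2 (within the scatter), which stayed within the scatter; it is the sole precedent and covers a smaller group than pentyl. On that basis no step beyond the scatter is expected in this assay, with the direction left open. Compound 3 is therefore estimated at 38%, with a range from 22% to 52%. The step this estimate means is a number 1 percentage points higher from compound 2 to compound 3 (within the scatter).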

Compound 3, a percentage reported as inhibition, in the whole organism at one dose (the size of the read-out at that dose, not a potency): 34%
The estimate for compound 3 lay 4 percentage points above the measured number; low and high end bracket the measured number.
By their numbers in this assay, from the lowest: compounds 1, 3 and 2 (each within the scatter of the next).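

In this assay, a pentyl group on the amide-type nitrogen extends the comparison beyond methyl and isopropyl, and a number 3 percentage points lower from compound 2 to compound 3 (within the scatter) is the step from the branched group. Against methyl, a number 4 percentage points higher from compound 1 to compound 3 (within the scatter) is likewise small, so none of the three listed groups on this nitrogen separates from another at this dose, and the larger pentyl group gives no reading beyond that of the smaller groups. Nothing measured here bears on why these changes leave the read-out within the scatter.

Still open, as far as these compounds go, is whether a benzyl group, or a chain carrying an amine or a carboxylic acid, in place of pentyl on the amide-type nitrogen would give a step beyond the scatter. From the compounds shown here alone, a longer chain than pentyl also remains open, as does any change to the shared core.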